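This account rests on a few compounds, and the source may have more. Where it says the series, first, only, none or still open, it means among the compounds named here.

Measured in a functional assay on BXPC-3 cells (Homo sapiens) for inhibition, read by MTT assay, with a stated time of 72 h; on this read-out higher numbers stand for weaker inhibition and lower numbers for stronger inhibition:
Compound 1 `O=C(Nc1cccc2cccnc12)c1ncccn1`: > 10000 nM, a limit of the assay
Compound 2 `O=C(Nc1cc(F)cc2cccnc12)c1cnccn1`: > 10000 nM, a limit of the assay
Compound 3 `COc1cc(NC(=O)c2cnccn2)c2ncccc2c1`: 470 nM

Compound 3 is the only one of the three with a true number. Compound 4 `COc1cc(NC(=O)c2ncccn2)c2ncccc2c1` has the same atoms as compound 3, joined differently, with pyrimidin-2-yl in place of pyrazin-2-yl on a carbonyl carbon.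

Among the compounds with values here, the one measured step, an at least 21-fold lower number from compound 2 to compound 3 (1.32 log units; beyond the scatter), is large, but it is methoxy in place of fluoro on an aromatic carbon, not this swap. It does show that a single change can matter greatly among these compounds, so the range must stay wide. Compound 1 carries pyrimidin-2-yl without the methoxy and gives > 10000 nM, a limit, which cannot size the swap.

Within the data shown here, with no measured step on this change, no shift beyond the scatter is expected in this assay. The expected change is a 1.5-fold higher number from compound 3 to compound 4 (0.17 log units; within the scatter). Compound 4 is expected at 700 nM, with an estimated range of 150 nM to 4000 nM.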

Compound 4, half-maximal inhibitory concentration: > 10000 nM
Compound 4 was reported as a limit; the forecaster's own chance of this, stated with the estimate: 15%; middle value at least 14-fold (1.15 log units) from the limit.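

In this assay, pyrimidin-2-yl and pyrazin-2-yl have the same atoms joined differently, yet this swap on the carbonyl carbon gives an at least 21-fold higher number from compound 3 to compound 4 (1.32 log units; beyond the scatter) and shows that the group at this place matters as much as the methoxy. The methoxy is therefore not enough on its own, since compound 4 carries it and still gives only a limit. The step that adds the methoxy to compound 1 cannot be read, because both of its values are limits: the limit of > 10000 nM in this assay, at which 3 of the 4 values shown sit.

From the compounds shown here alone, it remains open whether a phenyl or pyridin-2-yl group on the carbonyl carbon would give a true number in this assay as compound 3 does. Going by these compounds, it is also open whether an amine or a longer ether chain could take the place of the methoxy.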